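Inverting the Ring Stereocentre of Compound 1

The compounds below may be only part of what the source reports. "The series", "measured", "known", "first", "only" and "open" are said of these compounds alone.

Compounds measured so far:
compound 1 `COc1cc(NC(=O)[C@@H]2CSC(c3ccccc3)=N2)cc(OC)c1OC` — 5300 nM
compound 2 `COc1cc(NC(=O)[C@@H]2CSC(c3cc(OC)c(OC)c(OC)c3)N2)cc(OC)c1OC` — a limit only, > 20000 nM
compound 3 `COc1cc(NC(=O)[C@@H]2CSC(c3ccccc3)N2)cc(OC)c1OC` — a limit only, > 20000 nM

In a functional assay on PPC-1 cells (Homo sapiens) for cytotoxicity, read by sulforhodamine B assay, with a stated time of 48 h (on this read-out higher numbers stand for weaker inhibition and lower numbers for stronger inhibition), compound 1 gives 5300 nM. For compound 2 the assay reports only a limit, > 20000 nM. For compound 3 it likewise reports only a limit, > 20000 nM. Within the data shown here, compound 1 is thus the only compound with a measured number; the other two sit at the limit of > 20000 nM in this assay, at which 2 of the 3 values shown sit. Among the measured compounds shown here, nothing beyond this is available, and no step between two measured compounds has been recorded, so no measured change can be followed.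

Compound 4 `COc1cc(NC(=O)[C@H]2CSC(c3ccccc3)=N2)cc(OC)c1OC` has not yet been tested in this assay. (the two compounds have the same atoms and bonds and differ only in configuration as drawn: 1 of 1 stereo elements differ; a stereocentre at a saturated ring carbon is drawn R in compound 1 and S in compound 4). Since compound 1 and compound 4 share every atom and bond, the expected step from compound 1 to compound 4 rests on configuration alone. The writer expects the step of a 1.5-fold higher number from compound 1 to compound 4 (0.18 log units; within the scatter) to be modest, in the direction of weaker inhibition, and possibly within the scatter. Compound 4 is therefore estimated to give 8000 nM, in the range 2500 nM to 20000 nM.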

Compound 4, half-maximal inhibitory concentration: 3400 nM
Compound 4: middle estimate off by 2.4-fold (0.37 log units), on the high side; measured number inside the range.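

In this assay, inverting the stereocentre at the saturated ring carbon gives a 1.6-fold lower number from compound 1 to compound 4 (0.19 log units; within the scatter). Among these compounds, this is the first measured change in the set, and it shows that the configuration at this position, drawn R in compound 1 and S in compound 4, does not separate the two compounds in this read-out. The comparison isolates that one feature, since nothing else changes: the fact that compounds 1 and 4 differ only in the configuration as drawn

Going by these compounds, compounds 2 and 3 give no number to set beside this pair, only a limit of the assay: the limit of > 20000 nM in this assay, at which 2 of the 4 values shown sit. Whether an amine or a carboxylic acid on the shared core would shift the number, and whether the two configurations would then still match, stays open.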